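The source may report more compounds than this note shows. Statements on the series, on what has been measured and on what is new or still open speak of the compounds shown alone.

Three compounds have so far been put through a functional assay on Huh-7 cells (Homo sapiens), read by fluorescence and BrdU incorporation, with a stated time of 48 h, tested at 10 uM; a higher number here means a weaker effect of the compound at the concentration tested, a lower number a stronger effect. Compound 1 `COc1cc(O)c(C(=O)/C=C/c2ccc(F)cc2)c(OC)c1` is reported in this assay as "not active" (no number reported), with no number attached to it. Compound 2 `COc1cccc(/C=C/C(=O)c2c(OC)cc(OC)cc2OC)c1` gives 40% in this assay, and compound 3 `COc1cc(OC)c(C(=O)/C=C/c2ccc(Cl)cc2)c(OC)c1` gives 33%. The step of a number 7 percentage points lower from compound 2 to compound 3 (within the scatter) lies within the usual scatter, so compound 3 stands together with compound 2 among the two numbers that exist, and the two cannot be told apart on these data.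

Compound 4 `COc1cc(OC)c(C(=O)/C=C/c2ccc(Br)cc2)c(OC)c1` has not yet been measured. It differs from compound 3 by bromo in place of chloro on an aromatic carbon. Within the data shown here, no measured step exchanges one halogen for another; the only measured step, a number 7 percentage points lower from compound 2 to compound 3 (within the scatter), exchanges a different kind of group and stays within the scatter. Nothing in the measured compounds therefore points up or down for this change. Compound 4 is expected to land close to compound 3 in this assay, with an estimated step of a number 3 percentage points lower from compound 3 to compound 4 (within the scatter) that remains within the scatter. The estimate for compound 4 is 30%, with an expected range from 15% to 50%.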

Compound 4, a percentage reported as activity, at one concentration (the size of the read-out at that concentration, not a potency): 46%
Estimate against measurement, compound 4: 16 percentage points below; low and high end bracket the measured number.
By their numbers in this assay, from the lowest: compounds 3, 2 and 4 (each within the scatter of the next, the first and the last beyond it).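

In this assay, the halogen on this aromatic carbon, para to a large group, proves not to be a freely interchangeable detail: bromo in place of chloro gives a number 13 percentage points higher from compound 3 to compound 4 (beyond the scatter) and, with a higher number meaning a weaker effect, the bromo compound does less at the concentration tested. Among these compounds, this is the first step in the set to clear the usual scatter, although it is modest in size, and it shows that even a swap of one halogen for the next can be read in this assay. The other new comparison, a change of the whole aryl group, gives a number 6 percentage points higher from compound 2 to compound 4 (within the scatter) and so does not separate 4-bromophenyl from 3-methoxyphenyl, while nothing measured here addresses why chloro and bromo differ.

On these data alone, this chloro-to-bromo step is seen only once, on one shared core and at one concentration, so whether it would recur on another core remains unknown. As far as these compounds go, how a group of a different kind, such as an amine or a carboxylic acid, would behave on this same aromatic carbon also remains open.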